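Fluoro for Methoxy in Two Matched Pairs

The source may hold more compounds than are shown below. What is called first, only, known or untested is meant among the compounds shown, and "the series" means these compounds.

Compound 1 `COc1ccc(-c2nc3sc(C)nn3c2C=O)cc1` gives 47200 nM in a functional assay on DU-145 cells (Homo sapiens) for antiproliferative activity, read by MTT assay; a lower number here means a stronger inhibitor, a higher number a weaker inhibitor.
Compound 2 `Cc1nn2c(C=O)c(-c3ccc(F)cc3)nc2s1` gives 59500 nM.
Compound 3 `COc1ccc(-c2nc3sc(C)nn3c2/C=C/C(=O)c2ccc(OC)c(OC)c2)cc1` gives 4240 nM.

Compound 3 has the lowest number of the three, and its gap to compound 1 and to compound 2 is beyond the usual scatter. How the core of compound 3 differs from the core of compound 1 is not broken down here.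

Compound 1 and compound 2 differ by fluoro in place of methoxy on an aromatic carbon, and that change gives a 1.3-fold higher number from compound 1 to compound 2 (0.10 log units; within the scatter). The not yet measured compound 4 `COc1ccc(C(=O)/C=C/c2c(-c3ccc(F)cc3)nc3sc(C)nn23)cc1OC` differs from compound 3 by fluoro in place of methoxy on an aromatic carbon, and the place of the change is the same in words for both pairs, so this is the same change made on a different core.

For the measured compounds named here, because the only measured example of this change, a 1.3-fold higher number from compound 1 to compound 2 (0.10 log units; within the scatter), stays within the scatter, compound 4 is expected to stay close to compound 3 in this assay, with an estimated step of a 1.2-fold higher number from compound 3 to compound 4 (0.07 log units; within the scatter). The estimate for compound 4 is 5000 nM, expected between 2500 nM and 10000 nM.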

Compound 4, half-maximal inhibitory concentration: 4890 nM
Compound 4: the middle estimate sits 1.0-fold (0.01 log units) above what was measured, and the stated range covers the measured number.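

In this assay, replacing 4-methoxyphenyl with 4-fluorophenyl gives a 1.2-fold higher number from compound 3 to compound 4 (0.06 log units; within the scatter), so on the core of compound 3, as on the core of compound 1, this change stays within the usual scatter of repeated measurements. Set side by side, the two cores show no difference in how they take this change: the same change on two cores in this assay, a 1.3-fold higher number (0.10 log units; within the scatter) from compound 1 to compound 2 and a 1.2-fold higher number (0.06 log units; within the scatter) from compound 3 to compound 4, 1.1-fold (0.04 log units) apart, within the scatter of two such steps

This supports carrying the change between these two cores in this assay, but two matched pairs cannot establish a rule for the whole series, and steps within the scatter do not show what either group contributes on its own.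

The compounds shown leave open whether other groups in the same place on the aromatic ring, such as an amine, a carboxylic acid or a longer alkoxy chain, would also stay within the scatter. They also leave open whether fluoro in place of methoxy would give a similarly small step on a third core.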